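The source may hold more compounds than are shown below. What is called first, only, known or untested is meant among the compounds shown, and "the series" means these compounds.

Measured compounds:
Compound 1, `O=C(CCc1nnc(-c2ccccc2)o1)c1ccccc1`, 18.7%
Compound 2, `Cc1ccc(C(=O)CCc2nnc(-c3ccccc3)o2)cc1`, 33.3%

In a functional assay on the whole organism (strain Wistar) for inhibition, with Rattus norvegicus as the target, with stated times of 30 min and 2 h, at a dose of 20 mg/kg by the oral route (on this read-out lower numbers stand for less inhibition and higher numbers for more inhibition at the one dose given (going by the name of the read-out)), compound 2 gives 33.3%, the higher of the two numbers recorded; compound 1 gives 18.7%. Within the data shown here, the one measured step, methyl in place of hydrogen on an aromatic carbon, runs a number 14.6 percentage points higher from compound 1 to compound 2 (beyond the scatter), a modest rise beyond the scatter.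

Compound 3, `Cc1ccc(C(=O)CCc2nnc(-c3ccccc3)o2)c(C)c1`, differs from compound 2 by methyl in place of hydrogen on an aromatic carbon. Among the measured compounds shown here, the only step that bears on this change is the one from compound 1 to compound 2, which was a number 14.6 percentage points higher from compound 1 to compound 2 (beyond the scatter). A second methyl on the same ring is expected to act in the same direction but more weakly, so the step to compound 3 is expected to be a number 6.7 percentage points higher from compound 2 to compound 3 (within the scatter), a rise that may not clear the scatter. In this assay compound 3 is therefore estimated at 40%, within a range from 25% to 56%.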

Compound 3, a percentage reported as inhibition, in the whole organism at one dose (the size of the read-out at that dose, not a potency): 36%
For compound 3 the middle estimate is 4 percentage points above the measured one; low and high end bracket the measured number.
By their numbers in this assay, from the lowest: compound 1; then compounds 2 and 3 (each within the scatter of the next).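

In this assay, methyl in place of hydrogen at the place ortho to a large group and meta to a methyl group gives a number 2.7 percentage points higher from compound 2 to compound 3 (within the scatter), so compound 3 cannot be told apart from compound 2 on this read-out. The same replacement at the earlier place gave a number 14.6 percentage points higher from compound 1 to compound 2 (beyond the scatter), so among these compounds the change has been seen to clear the scatter only once, and a second methyl on this ring shows no separable gain. Nothing available explains this difference between the two places.

The compounds shown leave open whether a chlorine atom or a methoxy group at this place would give a different number. They also leave open how a compound carrying only this ortho methyl, without the other methyl, would compare with compound 1.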